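A few compounds are considered here, and "the series" means these few. Any claim that something is new, unique, unknown or untested is made for them only; others in the source may bear on it.

Compound 1, whose structure is `COc1ccc(-c2cnc3nc(N)nc(N4CCN(C(=O)COc5ccccc5)CC4)c3n2)cc1OC`, was tested in a functional assay on cells (T-cell, Homo sapiens) for inhibition (a higher number here means a weaker inhibitor, a lower number a stronger inhibitor), and gave 4 nM. Going by the values given here, of the two compounds with numbers so far, compound 1 has the lower one. Among the compounds with values here, the other, compound 2 with the structure `CCOc1nc(N)nc2ncc(-c3ccc(CC)cc3)nc12`, gives in this assay a reading of 8200 nM; the two compounds differ in more than one place, so no single step connects them, but the gap between their numbers lies well beyond the scatter of repeated runs.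

The compound that follows is compound 3, with the structure `COc1ccc(-c2cnc3nc(N)nc(N4CCN(C(=O)Nc5ccc(C)cc5)CC4)c3n2)cc1OC`. It differs from compound 1 in one place: (4-methylphenyl)amino in place of phenoxymethyl on a carbonyl carbon. The acyl group on the ring nitrogen thus becomes a (4-methylphenyl)carbamoyl group in place of the (phenoxymethyl)carbonyl group.

Within the data shown here, no measured step of this kind is available to lean on. Since both groups hold one six-membered aromatic ring of carbon only and the change sits at the end of the molecule, compound 3 is expected to stay close to compound 1, with a step of a 1.5-fold higher number from compound 1 to compound 3 (0.18 log units; within the scatter) in this assay that is likely within the scatter or only slightly weakening. For compound 3 the estimate in this assay is 6 nM, expected to fall between 1.5 nM and 25 nM.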

Compound 3, half-maximal inhibitory concentration: 0.8 nM
For compound 3 the middle estimate is 7.5-fold (0.88 log units) above the measured one, and the stated range ends above it.
By their numbers in this assay, from the lowest: compound 3; then compound 1; then compound 2.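

Going by these compounds alone, replacing phenoxymethyl with (4-methylphenyl)amino on the carbonyl carbon gives a 5.0-fold lower number from compound 1 to compound 3 (0.70 log units; beyond the scatter) in this assay, the first step that can be read at a single place. It shows that the group on this carbonyl carbon affects the reading, even though the two groups have the same heavy-atom count and each holds one six-membered aromatic ring of carbon only; what differs is that one carbon and one oxygen give way to a nitrogen and a methyl-bearing ring, with 1 hydrogen-bond donor and 0 hydrogen-bond acceptors entering where 0 hydrogen-bond donors and 1 hydrogen-bond acceptor leave. Nothing available accounts for this gain, so it stands as an observation only.

The step changes the link to the ring and the substitution on the ring together, so the compounds shown leave open how much of it belongs to the amino link and how much to the methyl group. A plain phenylamino group, or a saturated cyclohexylamino group, on the same carbonyl carbon would be needed to separate these contributions.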